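Phenoxy in Place of Tert-Butyl on the Sulfonamide Ring

This account rests on a few compounds, and the source may have more. Where it says the series, first, only, none or still open, it means among the compounds named here.

Of the compounds shown here, three built on one shared core have been measured in an assay on isolated protein for inhibition of Nicotinamide phosphoribosyltransferase (Homo sapiens), read by WST assay, with stated times of 60 min, 5 min and 30 min, in the presence of a further agent that is not named here; on this read-out lower numbers stand for stronger inhibition and higher numbers for weaker inhibition. Compound 1 `CCc1ccc(NS(=O)(=O)c2cccc(CCCCCCNC(=O)/C=C/c3cccnc3)c2)cc1` gives 31.5 nM. Compound 2 `CC(C)(C)c1ccc(NS(=O)(=O)c2cccc(CCCCCCNC(=O)/C=C/c3cccnc3)c2)cc1` gives 9.47 nM, and compound 3 `O=C(/C=C/c1cccnc1)NCCCCCCc1cccc(S(=O)(=O)Nc2ccc(F)c(Cl)c2)c1` gives 9.7 nM. Compound 2 holds the lowest number of the three, but the step of a 1.0-fold higher number from compound 2 to compound 3 (0.01 log units; within the scatter) lies within the usual scatter, so the two cannot be ranked against each other. Only compound 1 stands clearly apart, as the step of a 3.3-fold lower number from compound 1 to compound 2 (0.52 log units; beyond the scatter) is beyond the scatter.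

Compound 4 `O=C(/C=C/c1cccnc1)NCCCCCCc1cccc(S(=O)(=O)Nc2ccc(Oc3ccccc3)cc2)c1` differs from compound 2 in one place: phenoxy in place of tert-butyl on an aromatic carbon. Among the compounds with values here, no measured step exchanges a group for a phenoxy, so the measured steps bear on this change only indirectly. What they do show is that the step of a 3.2-fold lower number from compound 1 to compound 3 (0.51 log units; beyond the scatter), which alters the same aryl ring in a quite different way, ends at a number close to that of compound 2. Changes on this ring have so far moved the number only modestly, and none has yet pushed it below the range compound 2 already occupies. A step of a 1.5-fold higher number from compound 2 to compound 4 (0.17 log units; within the scatter) is therefore expected for compound 4, within the scatter. In this assay compound 4 is expected to give 14 nM, with a range from 5 nM to 40 nM.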

Compound 4, half-maximal inhibitory concentration: 13.1 nM
Estimate against measurement, compound 4: 1.1-fold (0.03 log units) above; measured number inside the range.
By their numbers in this assay, from the lowest: compounds 2, 3 and 4 (each within the scatter of the next); then compound 1.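

In this assay, the step of a 1.4-fold higher number from compound 2 to compound 4 (0.14 log units; within the scatter) shows that this aromatic carbon, para to a large group, can carry phenoxy, with its extra six-membered aromatic ring and its hydrogen-bond acceptor, with no change that can be told from scatter, even though tert-butyl has no ring and no acceptor. The step of a 2.4-fold lower number from compound 1 to compound 4 (0.38 log units; beyond the scatter), by contrast, lies beyond the scatter, so among the three groups seen at this carbon, ethyl stands apart from both tert-butyl and phenoxy, which are very different in shape and make-up but cannot be separated by their numbers. No supporting evidence bears on why these groups give such similar numbers, so the result describes what happens at this carbon without explaining it.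

The compounds shown leave open whether the ring or the oxygen of phenoxy matters more, a question that a plain phenyl or a methoxy group at the same carbon could help to answer. They also leave open how far this carbon's range extends, for example to an amine, a carboxylic acid or a longer chain.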